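This account rests on a few compounds, and the source may have more. Where it says the series, first, only, none or still open, it means among the compounds named here.

Measured compounds:
Compound 1 `CCCCn1cnc2c(Nc3cccc(Cl)c3)nc(NCOCc3ccc(/C=C/C(=O)Nc4ccccc4N)cc3)nc21`, which in a functional assay on NCI-H460 cells (Homo sapiens) for antiproliferative activity, read by CCK-8 assay, with a stated time of 72 h, tested at 8 uM (a lower number here means a weaker effect, a higher number a stronger effect of the compound at the concentration tested), compound 1 gives 51.1%.
Compound 2 `Nc1ccccc1NC(=O)/C=C/c1ccc(COCNc2nc(Nc3cccc(Cl)c3)c3ncn(C4CCCC4)c3n2)cc1`, for which compound 2 gives 46.1%.
Compound 3 `CC(C)n1cnc2c(Nc3cccc(Cl)c3)nc(NCOCc3ccc(/C=C/C(=O)Nc4ccccc4N)cc3)nc21`, for which compound 3 gives 61.1%.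

Compound 2 holds the lowest of the three numbers in this assay. Its nearest neighbour is compound 1, the step being a number 5 percentage points lower from compound 1 to compound 2 (within the scatter), which lies within the scatter, so no order between the two can be read. The furthest is compound 3, with a number 15 percentage points higher from compound 2 to compound 3 (beyond the scatter), a modest step beyond the scatter; the step of a number 10 percentage points higher from compound 1 to compound 3 (within the scatter) stays within the scatter.

Compound 4 `Nc1ccccc1NC(=O)/C=C/c1ccc(COCNc2nc(Nc3ccccc3)c3ncn(C4CCCC4)c3n2)cc1` has not yet been measured. Relative to compound 2 it differs as follows: hydrogen in place of chloro on an aromatic carbon. The three measured steps all concern the group on the aromatic nitrogen (butyl, cyclopentyl, isopropyl); none touches the chloro on the six-membered aromatic ring of carbon only, so none bears directly on this change. Data for a chloro to hydrogen exchange are absent from the series. With nothing to suggest a shift either way, the expectation for this assay is no step beyond the scatter, the estimated step being a number 1.1 percentage points lower from compound 2 to compound 4 (within the scatter). Compound 4 is accordingly estimated at 45%, with a range from 28% to 62%.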

Compound 4, a percentage reported as inhibition, at one concentration (the size of the read-out at that concentration, not a potency): 59.7%
Estimate against measurement, compound 4: 14.7 percentage points below; low and high end bracket the measured number.
By their numbers in this assay, from the lowest: compounds 2, 1, 4 and 3 (each within the scatter of the next, the first and the last beyond it).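

Hydrogen in place of chloro on an aromatic carbon of the 3-chlorophenyl group, tested in this assay, gives a number 13.6 percentage points higher from compound 2 to compound 4 (beyond the scatter). For the compounds shown here, this is the first change made away from the aromatic nitrogen, and it shows that this position also moves the read-out and that, with cyclopentyl on that nitrogen, the chloro is not needed for the effect: compound 4 gives 59.7% without it. Nothing available explains why the plain anilino group gives the higher number in this pair.

This rests on one pair at a single concentration, so it remains open whether the same exchange would give a step of similar size with butyl or isopropyl on the aromatic nitrogen, where the 3-chlorophenyl compounds are the only ones shown. Also open, going by these compounds, is how the read-out would respond at this aromatic carbon to a fluoro, a methyl, a methoxy or an amine, which would show whether hydrogen is a particular optimum here or chloro is simply a poor fit among many acceptable groups.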